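The source may hold more compounds than are shown below. What is called first, only, known or untested is meant among the compounds shown, and "the series" means these compounds.

Measured in a functional assay on MCF7 cells (Homo sapiens) for cytotoxicity, read by MTT assay, with a stated time of 72 h; a lower number here means a stronger inhibitor, a higher number a weaker inhibitor:

Compound 1, `O=C1c2c[n+]([O-])c3ccccc3c2C(=O)c2c1c1ccccc1n2Cc1cn([C@H]2O[C@H](CO)[C@@H](O)[C@H]2O)nn1`: 1490 nM
Compound 2, `O=C1c2c[n+]([O-])c3ccccc3c2C(=O)c2c1c1ccccc1n2CCCCN1CCNCC1`: 12000 nM
Compound 3, `CN1CCN(CCCCCCn2c3c(c4ccccc42)C(=O)c2c[n+]([O-])c4ccccc4c2C3=O)CC1`: 400 nM

Compound 1 stands second highest of the three numbers. Its nearest neighbour is compound 3, whose lower number lies beyond the scatter; compound 2 lies furthest away, with a higher number, again beyond the scatter. Within the data shown here, the one step between compounds that differ in a single place is a 30-fold lower number from compound 2 to compound 3 (1.48 log units; beyond the scatter). That step sits on the saturated chain carried by the core nitrogen and says nothing about the sugar attached to the triazole.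

Compound 4 is `O=C1c2c[n+]([O-])c3ccccc3c2C(=O)c2c1c1ccccc1n2Cc1cn([C@@H]2O[C@H](CO)[C@@H](O)[C@H](O)[C@H]2O)nn1`. Relative to compound 1 it shows (3,4,5-trihydroxy-6-(hydroxymethyl)oxan-2-yl in place of 3,4-dihydroxy-5-(hydroxymethyl)oxolan-2-yl on an aromatic nitrogen). Among the measured compounds shown here, no measured pair in this small set alters that sugar, so there is no step that bears on the change; the shared core and the triazole linker are untouched. With nothing to argue for a shift in either direction, the expectation for this assay is a step of no more than the usual scatter, with the estimated step of a 1.0-fold higher number from compound 1 to compound 4 (0.00 log units; within the scatter).

Compound 4 is therefore estimated at 1500 nM, with a range from 600 nM to 4000 nM.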

Compound 4, half-maximal inhibitory concentration: 590 nM
For compound 4 the middle estimate is 2.5-fold (0.41 log units) above the measured one; measured number below the stated range.
By their numbers in this assay, from the lowest: compounds 3 and 4 (each within the scatter of the next); then compound 1; then compound 2.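

Among these compounds, at the aromatic nitrogen of the five-membered aromatic ring with 3 nitrogen, this assay responds to the sugar itself: 3,4,5-trihydroxy-6-(hydroxymethyl)oxan-2-yl in place of 3,4-dihydroxy-5-(hydroxymethyl)oxolan-2-yl gives a 2.5-fold lower number from compound 1 to compound 4 (0.40 log units; beyond the scatter), a modest step but beyond the scatter, and the first reading at this position, with the shared core and the linker unchanged. The step is a bundled one, as the entering group has a six-membered non-aromatic ring, 4 hydrogen-bond donors and 5 defined stereocentres, where the leaving group has a five-membered non-aromatic ring, 3 hydrogen-bond donors and 4 defined stereocentres. No measurement available here accounts for the step.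

The compounds shown leave open which of these differences carries the step, and a six-membered sugar differing from compound 4 only in its stereocentres, or a five-membered sugar with one hydroxyl removed, would begin to separate them. They also leave open whether a sugar is needed at this nitrogen at all, a question that a plain hydroxyethyl chain, an amine or a carboxylic acid in its place would address.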